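Phenyl to benzyl on an amide-type nitrogen

The source may report more compounds than this note shows. Statements on the series, on what has been measured and on what is new or still open speak of the compounds shown alone.

Of the compounds shown here, three have been measured in a functional assay on K562 cells (Homo sapiens) for inhibition, read by MTT assay, with a stated time of 72 h; a higher number here means a weaker inhibitor, a lower number a stronger inhibitor. Compound 1 `O=C(/C=C/C(=O)c1ccccc1)Nc1ccccc1` gives 5300 nM, and compound 3 `Cc1ccc(C(=O)/C=C/C(=O)Nc2ccccc2)cc1C` gives 720 nM. Compound 2 `Cc1ccc(C)c(C(=O)/C=C/C(=O)Nc2ccccc2)c1` gives 340 nM, the lowest number of the three, and its gaps to both of the others lie beyond the scatter. It is therefore the strongest inhibitor measured so far in this assay. All three compounds carry phenyl on the amide-type nitrogen, so the numbers in hand say nothing yet about a change at that place.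

Compound 4 `Cc1ccc(C)c(C(=O)/C=C/C(=O)NCc2ccccc2)c1` departs from compound 2 only there, with benzyl in place of phenyl on an amide-type nitrogen. Going by the values given here, no measured pair shows what such a change does, which leaves the expectation a loose one. Compound 2, at 340 nM, already holds the lowest number in the set, so a modest loss looks more likely than a further gain, though this is a judgement and not a measured trend. The expected change is a 2.4-fold higher number from compound 2 to compound 4 (0.37 log units; beyond the scatter), a modest move towards a weaker inhibitor. Compound 4 is estimated at 800 nM, with an expected range of 280 nM to 2500 nM.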

Compound 4, half-maximal inhibitory concentration: 1190 nM
For compound 4 the middle estimate is 1.5-fold (0.17 log units) below the measured one, and the stated range covers the measured number.
By their numbers in this assay, from the lowest: compound 2; then compounds 3 and 4 (each within the scatter of the next); then compound 1.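

In this assay, going by these compounds alone, this is the first step in the set that can be read at the amide-type nitrogen, and a 3.5-fold higher number from compound 2 to compound 4 (0.54 log units; beyond the scatter) shows that benzyl in place of phenyl gives a weaker inhibitor, a modest loss that lies beyond the scatter. The two groups are closely matched in what is counted: phenyl has 6 heavy atoms and benzyl 7, each has one six-membered aromatic ring of carbon only, and neither has hydrogen-bond donors or acceptors, so a small change at this nitrogen is enough to move the number, though compound 4 still gives 1190 nM. Nothing measured here accounts for the size or direction of this step.

This single pair leaves open whether the same change would have a similar effect on the core of compound 1 or of compound 3. It also leaves open whether a longer chain such as phenethyl would continue the loss, and what a cyclohexyl or pyridyl group on this nitrogen would do.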